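Swapping the fused bicycle on a chloropyridine sulfonamide

This account rests on a few compounds, and the source may have more. Where it says the series, first, only, none or still open, it means among the compounds named here.

Among the compounds that returned a number in an assay on U-87MG ATCC cells for inhibition of RAC-alpha serine/threonine-protein kinase (Homo sapiens), read by AlphaScreen, with a stated time of 2 h (a lower number here means a stronger inhibitor, a higher number a weaker inhibitor), compound 3 `O=S(=O)(Nc1cc(-c2ccc3nccn3n2)cnc1Cl)c1ccc(F)cc1` stands lowest, compound 3 giving 50 nM. The nearest is compound 2 `O=S(=O)(Nc1cc(-c2ccc3nccn3c2)cnc1Cl)c1ccc(F)cc1`, for which compound 2 gives 574 nM, the step being an 11-fold lower number from compound 2 to compound 3 (1.06 log units; beyond the scatter). Compound 1 `O=S(=O)(Nc1cc(-c2ccc3nc[nH]c3c2)cnc1Cl)c1ccc(F)cc1` returned only a limit, compound 1 sitting at > 12000 nM; this is the limit of > 12000 nM in this assay, at which 1 of the 3 values shown sits. The step from compound 1 is an at least 240-fold lower number from compound 1 to compound 3 (2.38 log units; beyond the scatter), and likewise an at least 20-fold lower number from compound 1 to compound 2 (1.32 log units; beyond the scatter).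

Compound 4 `O=S(=O)(Nc1cc(-c2ccc3ncoc3c2)cnc1Cl)c1ccc(F)cc1` differs from compound 3 in one place: a group of 9 heavy atoms (7 carbon, 1 nitrogen, 1 oxygen; one five-membered aromatic ring with 2 hetero atoms, one six-membered aromatic ring of carbon only) in place of a group of 9 heavy atoms (6 carbon, 3 nitrogen; one five-membered aromatic ring with 2 hetero atoms, one six-membered aromatic ring with 2 hetero atoms), on an aromatic carbon. Going by the values given here, two measured steps bear on this. Compound 1, which also carries a six-membered aromatic ring of carbon only, lies at the limit, and the steps of an at least 240-fold lower number from compound 1 to compound 3 (2.38 log units; beyond the scatter) and an 11-fold lower number from compound 2 to compound 3 (1.06 log units; beyond the scatter) both run in the direction of a lower number as nitrogen enters the six-membered ring. Compound 4 is therefore expected to give a clearly higher number, the step of a 60-fold higher number from compound 3 to compound 4 (1.78 log units; beyond the scatter) being estimated as large. For compound 4 the estimate in this assay is 3000 nM, within a range of 500 nM to 15000 nM.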

Compound 4, half-maximal inhibitory concentration: > 12000 nM
Compound 4: only a limit was reported; the forecaster's own chance of this, stated with the estimate: 30%; at least 4.0-fold (0.60 log units) between middle value and limit.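

Replacing the group of compound 3 with 1,3-benzoxazol-6-yl on this aromatic carbon gives an at least 240-fold higher number from compound 3 to compound 4 (2.38 log units; beyond the scatter), and the same change from compound 2 gives an at least 20-fold higher number from compound 2 to compound 4 (1.32 log units; beyond the scatter), so a second group with a six-membered aromatic ring of carbon only falls far behind both groups with nitrogen in that ring. Across all four compounds the weak result follows that carbon-only ring, with no compound going against it, which shows that it is not peculiar to 1H-benzimidazol-6-yl. The result for compound 4 is a limit and not a number, so the step between compound 1 and compound 4 cannot be read: the limit of > 12000 nM in this assay, at which 2 of the 4 values shown sit.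

Still open, going by these compounds, is whether a benzoxazole-type group with nitrogen in its six-membered ring would recover the lost inhibition. Also open, on these data alone, is how an amine or a methoxy group on the fused bicycle of compound 3 would change its number.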